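The compounds below may be only part of what the source reports. "The series", "measured", "known", "first", "only" and "open" are said of these compounds alone.

Compound 1, `ClCc1ccc(Cn2cnc3c(Cl)ncnc32)cc1`: in a functional assay on OVCAR-4 cells (Homo sapiens) for cytotoxicity, read by sulforhodamine B assay, with a stated time of 48 h (a higher number here means that more compound is tolerated, a lower number that less compound is tolerated), compound 1 gives > 100000 nM, which is a limit of the assay and not a number.
Compound 2, `Nc1nc(Cl)c2ncn(Cc3ccc(CCl)cc3)c2n1`: compound 2 gives 57500 nM.
Compound 3, `ClCc1ccccc1Cn1cnc2c(Cl)ncnc21`: compound 3 gives 45700 nM.

Compound 2 differs from compound 1 by amino in place of hydrogen on an aromatic carbon. The step is an at least 1.7-fold lower number from compound 1 to compound 2 (0.24 log units; that floor lies within the scatter); its floor is fixed because the limit of > 100000 nM in this assay, at which 1 of the 3 values shown sits, bounds the value of compound 1, so the true size of the step is not known.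

Compound 3 is built from the same atoms as compound 1, joined differently; the difference between the two cores is not broken down here. The value of compound 3 and the value of compound 2 lie within the usual scatter of each other, so no order is drawn from them.

Compound 4, `Nc1nc(Cl)c2ncn(Cc3ccccc3CCl)c2n1`, has not been measured in this assay. It differs from compound 3 by amino in place of hydrogen on an aromatic carbon, the same change that separates compound 2 from compound 1. A lowering of the number is expected here as well, because an at least 1.7-fold lower number from compound 1 to compound 2 (0.24 log units; that floor lies within the scatter) went that way, and the estimate is a 1.5-fold lower number from compound 3 to compound 4 (0.18 log units; within the scatter), kept modest because the earlier step rests on a limit.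

For compound 4 the expected value is 30000 nM, with a likely range from 12000 nM to 80000 nM.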

Compound 4, concentration lethal to 50% of the cells: 50100 nM
Compound 4: the middle estimate sits 1.7-fold (0.22 log units) below what was measured; the range from low to high includes it.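

In this assay, amino in place of hydrogen on an aromatic carbon, here between two ring nitrogen atoms, gives a 1.1-fold higher number from compound 3 to compound 4 (0.04 log units; within the scatter), and on the core of compound 3 this step therefore shows no readable effect of the change. Set beside the step on the other core, the result does not settle whether the change transfers: the same change on two cores in this assay, an at least 1.7-fold lower number (0.24 log units; that floor lies within the scatter) from compound 1 to compound 2 and a 1.1-fold higher number (0.04 log units; within the scatter) from compound 3 to compound 4; the limit leaves it open whether they differ Compound 1 gives > 100000 nM, which is a limit of the assay and not a number; the true size of the first step stays unknown, and the two steps show neither that the change transfers from one core to the other nor that it fails to.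

The compounds shown leave open whether another group on the same aromatic carbon, such as a methylamino or a hydroxyl, would give a value that stands apart from those of the amino compounds on either core. They also leave open whether replacing the chloromethyl group with a hydroxymethyl or a plain methyl would move the number in this assay, and whether the amino step could be read on a core whose starting value is not a limit and lies clear of the scatter.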